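The source may report more compounds than this note shows. Statements on the series, on what has been measured and on what is new or still open speak of the compounds shown alone.

Measured compounds:
compound 1 `CC1=C(C(=O)OC(C)(C)C)C(c2ccsc2)NC(=O)N1`: 47%
compound 2 `CCNC(=O)C1=C(C)NC(=O)NC1c1ccco1`: 1%
compound 3 `CCNC(=O)C1=C(C)NC(=O)NC1c1ccoc1`: 2%

In an assay on membranes from HEK293 cells for displacement of a labelled ligand from adenosine receptor A2b (Homo sapiens), read by scintillation counting, with a stated time of 30 min, tested at 1 uM (on this read-out lower numbers stand for less inhibition and higher numbers for more inhibition at the one concentration tested (going by the name of the read-out)), compound 3 gives 2%, the second highest of the three numbers. Its nearest neighbour is compound 2, and the step of a number 1 percentage points higher from compound 2 to compound 3 (within the scatter) is within the scatter, so the two furyl attachment points cannot be told apart on these data. Among the measured compounds shown here, compound 1 sits far higher, but it differs from compound 3 in more than one place, so no single step is drawn between the two and its number shows only that a much higher value is reachable within the shared core.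

Compound 4 `CCNC(=O)C1=C(C)NC(=O)NC1c1ccsc1` is the next member. The change from compound 3 is thiophen-3-yl in place of furan-3-yl on a saturated ring carbon. For the measured compounds named here, the only measured step, the one from compound 2 to compound 3, swapped the attachment point of the same group and stayed within the scatter; no measured step exchanges oxygen for sulfur with the ethylcarbamoyl group held constant. The step of a number 4 percentage points higher from compound 3 to compound 4 (within the scatter) is therefore expected to be small, most likely none beyond the scatter, with any movement more likely upward than downward given that the highest number in the set belongs to a thiophen-3-yl compound. Compound 4 is estimated at 6%, with a range from 0% to 22%.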

Compound 4, a percentage reported as inhibition, at one concentration (the size of the read-out at that concentration, not a potency): 1%
Estimate against measurement, compound 4: 5 percentage points above; the range from low to high includes it.
By their numbers in this assay, from the lowest: compounds 2, 4 and 3 (each within the scatter of the next); then compound 1.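

The decisive comparison is a number 46 percentage points lower from compound 1 to compound 4 (beyond the scatter) in this assay. Among the compounds shown here, it is the first single-place comparison that reaches compound 1: with thiophen-3-yl held constant, ethylamino in place of tert-butoxy on the carbonyl carbon separates the two compounds, so thiophen-3-yl alone does not carry the higher number. With the ethylcarbamoyl group held constant, the changes on the saturated ring carbon give a number 1 percentage points lower from compound 3 to compound 4 (within the scatter) and no change at the digits printed from compound 2 to compound 4 (within the scatter), so furan-2-yl, furan-3-yl and thiophen-3-yl cannot be told apart in this setting. Nothing in the data presented accounts for the size of the step at the carbonyl carbon.

On these data alone, it remains open whether the group on the saturated ring carbon matters when tert-butoxy is present, as a furan-3-yl counterpart of compound 1 would show. Also open, as far as these compounds go, is how far the number follows the group on the carbonyl carbon when ethylamino or tert-butoxy gives way to methoxy, a longer chain on the amide nitrogen, or a free carboxylic acid.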